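Trifluoromethylpyridinyl amide in place of cyanophenyl amide

This account rests on a few compounds, and the source may have more. Where it says the series, first, only, none or still open, it means among the compounds named here.

Measured so far:
compound 1 `CCOC(=O)c1sc(-c2cccc(NC(=O)c3ccc(C(F)(F)F)cc3)c2)nc1Nc1ccc(N2CCN(C)CC2)cc1`: 18.4%
compound 2 `CCOC(=O)c1sc(-c2cccc(NC(=O)c3ccc(F)cc3)c2)nc1Nc1ccc(N2CCN(C)CC2)cc1`: 3.53%
compound 3 `CCOC(=O)c1sc(-c2cccc(NC(=O)c3ccc(C#N)cc3)c2)nc1Nc1ccc(N2CCN(C)CC2)cc1`: 97.5%

Compound 3 stands highest of the three in a functional assay on Ramos cells (Homo sapiens) for antiproliferative activity, read by CCK-8 assay, with a stated time of 72 h, tested at 40 uM; on this read-out lower numbers stand for less inhibition and higher numbers for more inhibition at the one concentration tested (going by the name of the read-out); its nearest neighbour is compound 1, reached by a number 79.1 percentage points higher from compound 1 to compound 3 (beyond the scatter), and its furthest is compound 2, reached by a number 94 percentage points higher from compound 2 to compound 3 (beyond the scatter). Compound 4 `CCOC(=O)c1sc(-c2cccc(NC(=O)c3ccc(C(F)(F)F)cn3)c2)nc1Nc1ccc(N2CCN(C)CC2)cc1` differs from compound 3 in one place: 5-(trifluoromethyl)pyridin-2-yl in place of 4-cyanophenyl on a carbonyl carbon. Among the compounds with values here, the bearing step is the one from compound 1 to compound 3, where cyano replaced trifluoromethyl and the change was large; compound 4 returns to trifluoromethyl, now on a pyridinyl ring. Within the data shown here, no measured pair tells what the ring nitrogen does. A large drop in this assay is therefore expected for compound 4, roughly a number 72.5 percentage points lower from compound 3 to compound 4 (beyond the scatter), and its estimated value is 25%, within 5% to 60%.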

Compound 4, a percentage reported as inhibition, at one concentration (the size of the read-out at that concentration, not a potency): 19%
Compound 4: middle estimate off by 6 percentage points, on the high side; the measured number falls inside the stated range.
By their numbers in this assay, from the lowest: compound 2; then compounds 1 and 4 (each within the scatter of the next); then compound 3.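

In this assay, swapping the phenyl ring for pyridinyl under the trifluoromethyl group changes nothing readable, with a number 0.6 percentage points higher from compound 1 to compound 4 (within the scatter), so the ring nitrogen does not recover what 4-cyanophenyl gives on this carbonyl carbon, as a number 78.5 percentage points lower from compound 3 to compound 4 (beyond the scatter) shows. The trifluoromethyl pyridinyl amide still separates from the 4-fluorophenyl amide, with a number 15.5 percentage points higher from compound 2 to compound 4 (beyond the scatter). Nothing measured here accounts for these differences. Still open, on these data alone, is whether a nitrile on the pyridinyl ring would hold the level of compound 3, and how a carboxylic acid or an amine would read in place of that nitrile.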